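The source may hold more compounds than are shown below. What is called first, only, known or untested is meant among the compounds shown, and "the series" means these compounds.

Compound 1 `Oc1cccc(-c2cc(-c3ccoc3)cc(-c3cccc(O)c3)n2)c1` carries two 3-hydroxyphenyl groups and a furan-3-yl group on its shared core. In a functional assay on HCT-15 cells (Homo sapiens) for cytotoxicity, read by CCK-8 assay (on this read-out lower numbers stand for stronger inhibition and higher numbers for weaker inhibition), compound 1 gives 1020 nM. Compound 2 `Oc1ccc(-c2cc(-c3ccoc3)cc(-c3cccc(O)c3)n2)cc1` differs from it by 4-hydroxyphenyl in place of 3-hydroxyphenyl on an aromatic carbon; in this assay compound 2 gives 930 nM, so the step of a 1.1-fold lower number from compound 1 to compound 2 (0.04 log units; within the scatter) leaves the two within the scatter of each other.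

Compound 3 `Oc1ccc(-c2cc(-c3cccnc3)cc(-c3cccc(O)c3)n2)cc1` differs from compound 2 by pyridin-3-yl in place of furan-3-yl on an aromatic carbon. For compound 3 this assay reports only a limit, > 50000 nM, which is the limit of > 50000 nM in this assay, at which 1 of the 3 values shown sits. The step of an at least 53-fold higher number from compound 2 to compound 3 (1.73 log units; beyond the scatter) is therefore large, and the difference between the core of compound 1 and the core of compound 3 is not broken down here.

Compound 4 `Oc1ccc(-c2cc(-c3cccnc3)cc(-c3ccc(O)cc3)n2)cc1` is not yet measured. It differs from compound 3 by 4-hydroxyphenyl in place of 3-hydroxyphenyl on an aromatic carbon. Within the data shown here, this is the same kind of change as the one from compound 1 to compound 2, though its surroundings differ: in compound 3 the carbon is meta to a 4-hydroxyphenyl group and meta to a pyridin-3-yl group, whereas in compound 1 it was meta to a 3-hydroxyphenyl group and meta to a furan-3-yl group. Since the earlier step of a 1.1-fold lower number from compound 1 to compound 2 (0.04 log units; within the scatter) stayed within the scatter, the step that the limit leaves unreadable from compound 3 to compound 4 is expected to be similarly small, and because compound 3 gave only the limit > 50000 nM the result for compound 4 is expected to be a limit too. The estimate for compound 4 in this assay is 60000 nM, spanning 20000 nM to 200000 nM.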

Compound 4, half-maximal inhibitory concentration: 840 nM
The estimate for compound 4 lay 71-fold (1.85 log units) above the measured number; the whole stated range lies above it.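

In this assay, 4-hydroxyphenyl in place of 3-hydroxyphenyl gives an at least 59-fold lower number from compound 3 to compound 4 (1.77 log units; beyond the scatter), so the size of this step does not carry over from the core of compound 1 to the core of compound 3: the same change on two cores in this assay, a 1.1-fold lower number (0.04 log units; within the scatter) from compound 1 to compound 2 and an at least 59-fold lower number (1.77 log units; beyond the scatter) from compound 3 to compound 4, at least 54-fold (1.73 log units) apart, beyond the scatter of two such steps

Compound 3 is recorded only at a limit of this assay, so the new step has no exact size: the limit of > 50000 nM in this assay, at which 1 of the 4 values shown sits.

The two pairs show that, in this series, the outcome of this one change cannot be read across from one core to another, but they do not show which feature of the cores sets the outcome or how the change would behave on any further core.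

The compounds shown leave open how 3-hydroxyphenyl and 4-hydroxyphenyl groups would compare on a core that carries a thiophene or a plain phenyl group where compound 1 has furan-3-yl and compound 3 has pyridin-3-yl. They also leave open what would follow if an amine or a carboxylic acid took the place of the hydroxyl on these hydroxyphenyl groups.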